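The source may report more compounds than this note shows. Statements on the series, on what has been measured and on what is new or still open speak of the compounds shown alone.

Series of aminothiophene ketones with an arylpiperazine on the methylene arm, read out in a functional assay on CHO cells with adenosine receptor A1 (Homo sapiens) as the target, read by cAMP accumulation and immunoassay, with a stated time of 6 min, tested at 1 uM; a higher number here means a weaker effect of the compound at the concentration tested, a lower number a stronger effect. Compound 1 `Nc1scc(CN2CCN(c3ccc(Cl)cc3Cl)CC2)c1C(=O)c1ccc(Cl)cc1` gives -54% in this assay. Compound 2 `Nc1scc(CN2CCN(c3ccccc3C(F)(F)F)CC2)c1C(=O)c1ccc(Cl)cc1` gives -39% in this assay, and compound 3 `Nc1scc(CN2CCN(c3ccc(Cl)c(C(F)(F)F)c3)CC2)c1C(=O)c1ccc(Cl)cc1` gives -47% in this assay. Among the three numbers compound 3 stands second highest; its nearest neighbour is compound 1, and the two lie within the scatter of each other, as do compound 3 and compound 2. For the measured compounds named here, the one step beyond the scatter is a number 15 percentage points higher from compound 1 to compound 2 (beyond the scatter); the others, a number 7 percentage points higher from compound 1 to compound 3 (within the scatter) and a number 8 percentage points lower from compound 2 to compound 3 (within the scatter), do not separate.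

Compound 4 `Nc1scc(CN2CCN(c3ccncc3)CC2)c1C(=O)c1ccc(Cl)cc1` is the next member. The change from compound 3 is pyridin-4-yl in place of 4-chloro-3-(trifluoromethyl)phenyl on an amine nitrogen in a ring. Going by the values given here, no measured step covers this change: every step so far swaps one substituted carbocyclic aryl for another, and the largest of them, from compound 1 to compound 2, is only modest. Compound 4 takes away the halogen and trifluoromethyl substitution altogether and brings in a ring with a hetero atom, a wider change than any measured one, so the number is expected to move upward by more than the scatter, with wide uncertainty. The expected step is a number 17 percentage points higher from compound 3 to compound 4 (beyond the scatter). Compound 4 is estimated at -30% in this assay, expected between -55% and -5%.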

Compound 4, a percentage reported as activity, at one concentration (the size of the read-out at that concentration, not a potency): -8.3%
Beside the measured number, compound 4's estimate is 21.7 percentage points below it; the measured number falls inside the stated range.
By their numbers in this assay, from the lowest: compounds 1, 3 and 2 (each within the scatter of the next, the first and the last beyond it); then compound 4.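

For the compounds shown here, at this position, on an amine nitrogen in a ring, this assay responds far more strongly to replacing the substituted carbocyclic aryl with pyridin-4-yl than to any exchange among compounds 1, 2 and 3: the read-out moves by a number 38.7 percentage points higher from compound 3 to compound 4 (beyond the scatter), by a number 30.7 percentage points higher from compound 2 to compound 4 (beyond the scatter) and by a number 45.7 percentage points higher from compound 1 to compound 4 (beyond the scatter), whereas the only earlier step beyond the scatter was a number 15 percentage points higher from compound 1 to compound 2 (beyond the scatter). All three new steps are large and point the same way, so compound 4 has the weakest effect of the four compounds at the concentration tested, and the position is shown to tolerate much less change than the earlier compounds suggested. No available measurement bears on the reason for this drop.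

The change removes chlorine and trifluoromethyl and introduces a ring nitrogen in a single step, so the compounds shown cannot assign the drop to either alteration. An unsubstituted phenyl on the same piperazine nitrogen, or a pyridine ring carrying chlorine or trifluoromethyl, would be needed to separate the two contributions.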